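The source may report more compounds than this note shows. Statements on the series, on what has been measured and on what is new or still open speak of the compounds shown alone.

Compound 3 `CCN1CCN(CC(=O)NC2(c3ccc(Cl)c(Cl)c3)C(=O)Nc3cc(Cl)cc(Cl)c32)CC1=O` stands at the weak end of this small set: in an in vitro functional assay on CHO-CREluc cells for antagonist activity at growth hormone secretagogue receptor type 1 (Homo sapiens), read by a luciferase reporter, with a stated time of 4 h (a higher number here means a weaker inhibitor, a lower number a stronger inhibitor), compound 3 gives 2780 nM, while compound 1 `CCN1CCC(CC(=O)NC2(c3ccc(Cl)c(Cl)c3)C(=O)Nc3cc(Cl)cc(Cl)c32)CC1` gives 1 nM and compound 2 `C=CCN1CCN(CC(=O)NC2(c3ccc(Cl)c(Cl)c3)C(=O)Nc3cc(Cl)cc(Cl)c32)CC1` gives 38 nM. Compound 4 `CCN1CCN(CC(=O)NC2(c3ccc(Cl)c(Cl)c3)C(=O)Nc3cc(Cl)cc(Cl)c32)CC1` differs from compound 3 by 4-ethylpiperazin-1-yl in place of 4-ethyl-3-oxopiperazin-1-yl on a saturated chain carbon bound to a carbonyl carbon. Within the data shown here, two measured steps bear on this change. The step of a 73-fold higher number from compound 2 to compound 3 (1.86 log units; beyond the scatter) brought in the same 3-oxo group together with an allyl-to-ethyl swap, and the step of a 2800-fold higher number from compound 1 to compound 3 (3.44 log units; beyond the scatter) reached compound 3 from a different starting ring; both ran toward weaker inhibition. Reversing the oxo part of that change, compound 4 is therefore expected to show a large drop in the number, a 70-fold lower number from compound 3 to compound 4 (1.84 log units; beyond the scatter). The estimate for compound 4 is 40 nM, with a range from 10 nM to 160 nM.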

Compound 4, half-maximal inhibitory concentration: 7 nM
For compound 4 the middle estimate is 5.7-fold (0.76 log units) above the measured one; measured number below the stated range.
By their numbers in this assay, from the lowest: compound 1; then compound 4; then compound 2; then compound 3.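

Taking away only the ring carbonyl, with the ethyl group kept, gives a 400-fold lower number from compound 3 to compound 4 (2.60 log units; beyond the scatter) and so isolates a change that the earlier steps always carried along with another difference. With that carbonyl gone, the remaining differences are much smaller: 4-ethylpiperazin-1-yl in place of 4-allylpiperazin-1-yl gives a 5.4-fold lower number from compound 2 to compound 4 (0.73 log units; beyond the scatter) and, in place of 1-ethylpiperidin-4-yl, gives a 7.0-fold higher number from compound 1 to compound 4 (0.85 log units; beyond the scatter). No measurement shown explains the size of the carbonyl effect. On these data alone, it remains open whether a methyl or propyl group in place of the ethyl would keep this inhibition, and whether a carbonyl in the 1-ethylpiperidin-4-yl ring would cost as much.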